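Replacing Naphthalen-2-yl with 3,4-Dimethylphenyl in Compound 4

This account rests on a few compounds, and the source may have more. Where it says the series, first, only, none or still open, it means among the compounds named here.

Of the compounds shown here, three built on one shared core have been tested in a functional assay on cells (Pituitary gland cell) for antagonist activity at Gonadotropin-releasing hormone receptor (Rattus norvegicus); a lower number here means a stronger inhibitor, a higher number a weaker inhibitor. Compound 1 `O=[N+]([O-])c1cc2c(OCCC3CCCCN3)c(-c3ccc4ccccc4c3)c(O)nc2cc1Cl` carries a nitro group and gives 53 nM. Compound 2 `O=C(Nc1cc2c(OCCC3CCCCN3)c(-c3ccc4ccccc4c3)c(O)nc2cc1Cl)NC1CC1` carries a (cyclopropylcarbamoyl)amino group in its place and gives 68 nM; the step of a 1.3-fold higher number from compound 1 to compound 2 (0.11 log units; within the scatter) is small. Compound 3 `Cc1cc(C)cc(-c2c(O)nc3cc(Cl)c(NC(=O)Nc4cccnc4)cc3c2OCCC2CCCCN2)c1` carries a 3,5-dimethylphenyl group together with a different substituent and gives 20 nM. Among these three numbers compound 2 has the highest; compound 1 stands nearest, within the scatter, while compound 3 lies beyond the scatter with a lower number.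

Compound 4 `Cc1ccc(-c2c(O)nc3cc(Cl)c(NC(=O)NC4CC4)cc3c2OCCC2CCCCN2)cc1C` keeps the (cyclopropylcarbamoyl)amino group of compound 2 and alters only the aryl group: 3,4-dimethylphenyl in place of naphthalen-2-yl on an aromatic carbon.

For the measured compounds named here, no measured step bears directly on this change. Going by the values given here, the single measured step, a 1.3-fold higher number from compound 1 to compound 2 (0.11 log units; within the scatter), alters a different part of the molecule. Compound 3, which also carries a dimethylphenyl group, gives 20 nM, but it differs from compound 2 in two places, so its number cannot isolate the aryl swap on its own. The expected step is therefore modest, a 1.5-fold lower number from compound 2 to compound 4 (0.18 log units; within the scatter), leaning toward a lower number. Compound 4 is estimated to give about 45 nM, within a range from 15 nM to 140 nM.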

Compound 4, half-maximal inhibitory concentration: 6 nM
Estimate against measurement, compound 4: 7.5-fold (0.88 log units) above, outside the stated range (below it).
By their numbers in this assay, from the lowest: compound 4; then compound 3; then compounds 1 and 2 (each within the scatter of the next).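

In this assay, for the compounds shown here, the aryl group matters far more than the earlier compounds could show: 3,4-dimethylphenyl in place of naphthalen-2-yl gives an 11-fold lower number from compound 2 to compound 4 (1.05 log units; beyond the scatter), whereas the only earlier one-place change, made elsewhere on the molecule, gave a 1.3-fold higher number from compound 1 to compound 2 (0.11 log units; within the scatter). The number therefore responds strongly to the group on this aromatic carbon, ortho to a 2-(piperidin-2-yl)ethoxy group and ortho to a hydroxy group, and here the single-ring 3,4-dimethylphenyl group beats the two-ring naphthalen-2-yl group, at least with the (cyclopropylcarbamoyl)amino group in place. Nothing available explains why this swap has so large an effect.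

This single step cannot separate the loss of the second ring from the arrival of the two methyl groups, and comparing plain phenyl, 4-methylphenyl and 3,4-dichlorophenyl at this position would help to tell those apart. On these data alone, it also remains open whether 3,4-dimethylphenyl would bring a similar gain alongside the nitro group of compound 1.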